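A few compounds are considered here, and "the series" means these few. Any claim that something is new, unique, unknown or untested is made for them only; others in the source may bear on it.

Measured compounds:
- compound 1 `COc1ccccc1NC(=O)c1sccc1Sc1ccc([N+](=O)[O-])cc1`, in an ADME assay on H9 cells (Homo sapiens) for cytotoxicity, read by MTT assay, with a stated time of 7 days (a higher number here means that more compound is tolerated, a lower number that less compound is tolerated), compound 1 gives 472000 nM
- compound 2 `COc1ccccc1NC(=O)c1cc([N+](=O)[O-])ccc1Sc1ccc([N+](=O)[O-])cc1`, in this assay compound 2 gives "not determined" (no result reported)

Within the data shown here, compound 2 therefore has no value of its own in this assay; the only number in hand is that of compound 1, which carries a single nitro group and is tolerated at a high concentration. Compound 3 `COc1ccccc1NC(=O)c1cc(Cl)ccc1Sc1ccc([N+](=O)[O-])cc1` differs from compound 2 by one change: chloro in place of nitro on an aromatic carbon, meta to a large group and para to the (4-nitrophenyl)sulfanyl group. Among the measured compounds shown here, no measured step of this kind is available in this assay, so the size of the effect is not known from the data; compound 1 shows that the shared core with one nitro group is tolerated well, and a change at the other ring is expected to move the read-out, if at all, by no more than the usual scatter, or modestly downward. Compound 3 is therefore expected to give about 250000 nM, within a range of 60000 nM to 600000 nM.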

Compound 3, half-maximal cytotoxic concentration: 483000 nM
Compound 3: middle estimate off by 1.9-fold (0.29 log units), on the low side; low and high end bracket the measured number.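

No step can be read between compound 2 and compound 3 in this assay, since compound 2 has no number to set against that of compound 3. Nothing shown bears on the reason for this result. As far as these compounds go, what replacing nitro with chloro does to the tolerated concentration stays open.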